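Swapping methyl for carboxy on compound 3

The source may hold more compounds than are shown below. What is called first, only, known or untested is meant among the compounds shown, and "the series" means these compounds.

Compound 1 `CCOc1ccc(-c2cc3c(cn2)[nH]c(=O)n3-c2cc(OC)c(OC)c(OC)c2)cc1` gives 3730 nM
Compound 2 `CCOc1ccc(-c2cc3c(cn2)[nH]c(=O)n3-c2cc(OC)c(OC)c(OC)c2)cc1F` gives 2870 nM
Compound 3 `COc1ccc(-c2cc3c(cn2)[nH]c(=O)n3-c2cc(OC)c(OC)c(OC)c2)cc1C` gives 1410 nM

In a functional assay on HeLa cells (Homo sapiens) for antiproliferative activity, read by MTT assay, with a stated time of 48 h (a lower number here means a stronger inhibitor, a higher number a weaker inhibitor), compound 3 stands lowest of the three, at 1410 nM, making it the strongest inhibitor so far. Compound 4 `COc1ccc(-c2cc3c(cn2)[nH]c(=O)n3-c2cc(OC)c(OC)c(OC)c2)cc1C(=O)O` carries carboxy in place of methyl on an aromatic carbon, ortho to a methoxy group: carboxy in place of methyl on an aromatic carbon. Among the measured compounds shown here, two measured steps bear on this change, a 2.6-fold lower number from compound 1 to compound 3 (0.42 log units; beyond the scatter) and a 2.0-fold lower number from compound 2 to compound 3 (0.31 log units; beyond the scatter), and both are modest. Neither introduces a carboxy, so they guide the size only loosely. In this assay the expected step is a 3.5-fold higher number from compound 3 to compound 4 (0.55 log units; beyond the scatter), towards a weaker inhibitor and larger than those two. Compound 4 is estimated at 5000 nM, with an expected range of 1500 nM to 20000 nM.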

Compound 4, half-maximal inhibitory concentration: 5990 nM
For compound 4 the middle estimate is 1.2-fold (0.08 log units) below the measured one, and the stated range covers the measured number.
By their numbers in this assay, from the lowest: compound 3; then compounds 2, 1 and 4 (each within the scatter of the next, the first and the last beyond it).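

Carboxy in place of methyl at this spot, ortho to a methoxy group, gives a 4.2-fold higher number from compound 3 to compound 4 (0.63 log units; beyond the scatter) in this assay, the first change here that raises the number. Against the ethoxy-bearing compounds, the 3-carboxy-4-methoxyphenyl group gives a 2.1-fold higher number from compound 2 to compound 4 (0.32 log units; beyond the scatter) and then a 1.6-fold higher number from compound 1 to compound 4 (0.21 log units; within the scatter) so compound 4 has lost the lead held by compound 3 and sits level with compound 1.

A methyl ester, a primary amide or a hydroxymethyl at this spot could show whether the whole carboxy group matters or only part of it. No measurement shown explains the step.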